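Chloro-purine benzyl chlorides: effect of removing the amino group

The source may report more compounds than this note shows. Statements on the series, on what has been measured and on what is new or still open speak of the compounds shown alone.

Measured so far:
compound 1 `Nc1nc(Cl)c2ncn(Cc3ccccc3CCl)c2n1` — 19100 nM
compound 2 `ClCc1ccccc1Cn1cnc2nc(Cl)nc(Cl)c21` — > 100000 nM

Going by the values given here, compound 1 is the only member with an actual number in a functional assay on HT-29 cells (Homo sapiens) for cytotoxicity, read by sulforhodamine B assay, with a stated time of 48 h (on this read-out higher numbers stand for weaker inhibition of growth and lower numbers for stronger inhibition of growth), where compound 1 gives 19100 nM. Compound 2 returns only a limit of the assay in this assay, > 100000 nM; it sits at the limit of > 100000 nM in this assay, at which 1 of the 2 values shown sits, so no number is available for it. Compounds 1 and 2 share the benzyl chloride side chain and the core; compound 2 carries chloro where compound 1 carries amino.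

Compound 3 `ClCc1ccccc1Cn1cnc2c(Cl)ncnc21` is not yet measured. It differs from compound 1 by hydrogen in place of amino on an aromatic carbon. Among the compounds with values here, no measured step between two compounds differing in one place exists in this set, so no step size is known. Given that compound 2 lacks the amino group and rests at the limit, a loss is expected for compound 3, a step of a 2.6-fold higher number from compound 1 to compound 3 (0.42 log units; beyond the scatter) in this assay. Compound 3 is therefore estimated at 50000 nM, with a range from 15000 nM to 150000 nM.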

Compound 3, concentration for total growth inhibition: > 100000 nM
Compound 3 gave a limit, no number (the forecaster's own chance of this, stated with the estimate: 35%); at least 2.0-fold (0.30 log units) between middle value and limit.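

In this assay, going by these compounds alone, taking the amino group off the aromatic carbon between two ring nitrogen atoms gives an at least 5.2-fold higher number from compound 1 to compound 3 (0.71 log units; beyond the scatter) and is the first single change with a readable step. Compound 3 gives only a limit of the assay at > 100000 nM and so fixes a minimum size for this loss rather than its true size. Compound 2 and compound 3 both rest at a limit, so no step between them can be read, and amino is the only group at this carbon in the series that leaves a number: the limit of > 100000 nM in this assay, at which 2 of the 3 values shown sit.

From the compounds shown here alone, how far compound 3 lies past the limit remains open. Also open, going by these compounds, is whether a methylamino or hydroxyl group at this carbon would keep a number like that of compound 1.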